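Cyano for Nitro in a Series at the Cytotoxicity Limit

This account rests on a few compounds, and the source may have more. Where it says the series, first, only, none or still open, it means among the compounds named here.

Three compounds have been measured in an ADME assay on L02 cells (Homo sapiens) for cytotoxicity, read by MTT assay, with a stated time of 48 h; on this read-out lower numbers stand for stronger inhibition and higher numbers for weaker inhibition:

compound 1, `Cc1ccccc1Cn1cc(COc2ccc3c(=O)ccoc3c2)nn1`, gives > 300000 nM, which is a limit of the assay.
compound 2, `O=c1ccoc2cc(OCc3cn(Cc4cccc(Cl)c4)nn3)ccc12`, gives > 300000 nM, again a limit.
compound 3, `O=c1ccoc2cc(OCc3cn(Cc4ccc([N+](=O)[O-])cc4)nn3)ccc12`, gives > 300000 nM, also a limit.

All three compounds therefore stand at the same place: the limit of > 300000 nM in this assay, at which 3 of the 3 values shown sit. The steps between them, a step that the two limits leave unreadable from compound 1 to compound 2, a step that the two limits leave unreadable from compound 1 to compound 3 and a step that the two limits leave unreadable from compound 2 to compound 3, cannot be read, so the change of the benzyl substituent across these compounds has left no visible trace in this assay.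

Compound 4, `N#Cc1ccc(Cn2cc(COc3ccc4c(=O)ccoc4c3)nn2)cc1`, differs from compound 3 in a single respect: cyano in place of nitro on an aromatic carbon. No measured step bears readably on this change, because every shown value sits at the limit (the limit of > 300000 nM in this assay, at which 3 of the 3 values shown sit). The expectation is accordingly that compound 4 also shows no readable step, a step that the limit leaves unreadable from compound 3 to compound 4, and most likely returns a limit again. The estimate for compound 4 in this assay is 400000 nM, with a range from 150000 nM to 1000000 nM.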

Compound 4, half-maximal inhibitory concentration: > 300000 nM
Compound 4 gave a limit, no number (the forecaster's own chance of this, stated with the estimate: 85%); the middle value lies beyond the limit too.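

No new step can be read, since compound 4 stands with compound 1, compound 2 and compound 3 at a limit rather than a number: the limit of > 300000 nM in this assay, at which 4 of the 4 values shown sit.

In this assay, going by these compounds, it stays open how far each of these four compounds lies past that limit, and whether changing the benzyl substituent alters cytotoxicity at all.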